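Swapping the Amide Substituent on a Shared Core

The compounds below may be only part of what the source reports. "The series", "measured", "known", "first", "only" and "open" are said of these compounds alone.

In a functional assay on A549 cells (Homo sapiens) for antiproliferative activity, read by CCK-8 assay, with a stated time of 48 h (a higher number here means a weaker inhibitor, a lower number a stronger inhibitor), compound 1 `CNC(=O)c1cc(Oc2ccc(/C=C/c3ccccn3)cc2)ccn1` gives 17400 nM. Compound 2 `O=C(Nc1ccccc1)c1cc(Oc2ccc(/C=C/c3ccccn3)cc2)ccn1` gives 19100 nM in this assay, and the step of a 1.1-fold higher number from compound 1 to compound 2 (0.04 log units; within the scatter) shows the two compounds as indistinguishable. For compound 3 `O=C(NCc1ccc(F)cc1)c1cc(Oc2ccc(/C=C/c3ccccn3)cc2)ccn1` this assay reports only a limit, > 100000 nM. Compound 3 therefore stands at the weak end of the three, sitting at the limit of > 100000 nM in this assay, at which 1 of the 3 values shown sits, and the steps of an at least 5.7-fold higher number from compound 1 to compound 3 (0.75 log units; beyond the scatter) and an at least 5.2-fold higher number from compound 2 to compound 3 (0.71 log units; beyond the scatter) both record a clear loss when the (4-fluorobenzyl)amino group is present.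

Compound 4 `O=C(c1cc(Oc2ccc(/C=C/c3ccccn3)cc2)ccn1)N1CCCC1` has not yet been measured. It differs from compound 3 by pyrrolidin-1-yl in place of (4-fluorobenzyl)amino on a carbonyl carbon. The entering pyrrolidin-1-yl is smaller than the leaving group and, unlike the amide nitrogens of compounds 1, 2 and 3, carries no hydrogen-bond donor. The two measured steps into compound 3 bear on this change: removing the (4-fluorobenzyl)amino group should undo at least part of that loss, so the expected step is an at least 2.5-fold lower number from compound 3 to compound 4 (0.39 log units; beyond the scatter) toward a lower number, though the missing donor leaves the size uncertain. Compound 4 is thus estimated at 40000 nM in this assay, within a range from 12000 nM to 130000 nM.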

Compound 4, half-maximal inhibitory concentration: 15600 nM
The estimate for compound 4 lay 2.6-fold (0.41 log units) above the measured number; the range from low to high includes it.
By their numbers in this assay, from the lowest: compounds 4, 1 and 2 (each within the scatter of the next). At a limit, above all of these: compound 3.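

Only a limit of the assay is available for compound 3: the limit of > 100000 nM in this assay, at which 1 of the 4 values shown sits.

Against that limit, the change on the carbonyl carbon gives an at least 6.4-fold lower number from compound 3 to compound 4 (0.80 log units; beyond the scatter) and shows that a group without the amide hydrogen can still return to the level of the smaller amides in this assay. The comparisons with those amides give a 1.2-fold lower number from compound 2 to compound 4 (0.09 log units; within the scatter) and a 1.1-fold lower number from compound 1 to compound 4 (0.05 log units; within the scatter) and place compound 4 level with compound 1 and compound 2, so among the four compounds the amide hydrogen is not needed to hold this level, and compound 3 alone stands apart from that pattern.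

The compounds shown leave open whether the loss in compound 3 follows from the fluorine or from the benzyl group itself, a question that a plain benzylamino group on the same carbonyl carbon would help to separate. They also leave open whether a larger ring in place of pyrrolidin-1-yl, such as piperidin-1-yl or morpholin-4-yl, would stay at the level of compound 4 or fall away as compound 3 does.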